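From phenyl to 4-methoxyphenyl at the assay limit

The compounds below may be only part of what the source reports. "The series", "measured", "known", "first", "only" and "open" are said of these compounds alone.

compound 1 `C#C[C@@]1(O)[C@@H](CO)O[C@@H](n2cnc3c(-c4ccccc4)ncnc32)[C@@H]1O` gives > 250000 nM (a limit)
compound 2 `C#C[C@@]1(O)[C@@H](CO)O[C@@H](n2cnc3c(-c4ccc(C)cc4)ncnc32)[C@@H]1O` gives > 250000 nM (a limit)

In a functional assay on HeLa cells (Homo sapiens) for antiproliferative activity, read by cell counting, with a stated time of 72 h (a higher number here means a weaker inhibitor, a lower number a stronger inhibitor), compound 1 stands only at a limit (> 250000 nM) and has no number. Compound 3 `C#C[C@@]1(O)[C@@H](CO)O[C@@H](n2cnc3c(-c4ccc(OC)cc4)ncnc32)[C@@H]1O` carries methoxy in place of hydrogen on an aromatic carbon as methoxy in place of hydrogen on an aromatic carbon. Among the compounds with values here, the one measured step bearing on it, methyl in place of hydrogen on an aromatic carbon, is a step that the two limits leave unreadable from compound 1 to compound 2 and offers no size to carry over. The evidence is the limit of > 250000 nM in this assay, at which 2 of the 2 values shown sit, and so no step beyond the scatter is expected in this assay in either direction. For compound 3 the expected step is a number no higher from compound 1 to compound 3 (the limit leaves the size open) on this estimate. For compound 3 the estimated value is 250000 nM with an expected range from 100000 nM to 400000 nM on the same reasoning.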

Compound 3, half-maximal inhibitory concentration: > 250000 nM
Compound 3 was reported as a limit; the forecaster's own chance of this, stated with the estimate: 85%; the middle value sits exactly at the limit.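

In this assay compound 3 gives > 250000 nM, which is a limit, as are the values of compound 1 and compound 2, so no step among these three compounds can be read. The compounds shown leave open what size of step, if any, methyl or methoxy in place of hydrogen on an aromatic carbon brings in this assay.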